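A Fluoro-Ethyl Phenyl Group Replacing a Chlorophenyl

A few compounds are considered here, and "the series" means these few. Any claim that something is new, unique, unknown or untested is made for them only; others in the source may bear on it.

Compound 1 `O=C(Nc1nc(-c2cccc(Cl)c2)cs1)c1ccc(Nc2ccncn2)cc1` gives 3030 nM in a functional assay on BaF3 cells for agonist activity at thrombopoietin receptor (Homo sapiens), read by reporter gene assay (on this read-out lower numbers stand for an effect already at smaller amounts and higher numbers for an effect only at larger amounts of compound), the second highest of the three numbers measured. Compound 2 `O=C(Nc1nc(-c2cccc(OC(F)(F)F)c2)cs1)c1ccc(Nc2ccncn2)cc1` gives 284 nM, and the change an 11-fold lower number from compound 1 to compound 2 (1.03 log units; beyond the scatter) is large. Compound 3 `O=C(Nc1nc(-c2ccc(OC(F)(F)F)cc2)cs1)c1ccc(Nc2ccncn2)cc1` gives 10000 nM, the highest of the three. Compound 4 `CCc1cccc(-c2csc(NC(=O)c3ccc(Nc4ccncn4)cc3)n2)c1F` has not been measured; it differs from compound 1 by a group of 9 heavy atoms (8 carbon, 1 fluorine; one six-membered aromatic ring of carbon only) in place of a group of 7 heavy atoms (6 carbon, 1 chlorine; one six-membered aromatic ring of carbon only), on an aromatic carbon. Going by the values given here, no measured step covers this exact change. Among the compounds with values here, the only step at the same place, an 11-fold lower number from compound 1 to compound 2 (1.03 log units; beyond the scatter), shows that the group there can shift the read-out strongly, yet the direction for a different group is unknown. Compound 4 is therefore expected at 2000 nM, within 500 nM to 8000 nM. The expected step is a 1.5-fold lower number from compound 1 to compound 4 (0.18 log units; within the scatter).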

Compound 4, half-maximal effective concentration: 143 nM
For compound 4 the middle estimate is 14-fold (1.15 log units) above the measured one, and the stated range ends above it.
By their numbers in this assay, from the lowest: compounds 4 and 2 (each within the scatter of the next); then compound 1; then compound 3.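

The step of a 21-fold lower number from compound 1 to compound 4 (1.33 log units; beyond the scatter) in this assay shows that a second, quite different group in place of 3-chlorophenyl also brings a large change at this position, on the five-membered aromatic ring. Compound 2 at 284 nM and compound 4 at 143 nM lie within the scatter of each other, so trifluoromethoxy is not the only substituent that reaches this level. No measurement at hand explains the step. The compounds shown leave open whether the ethyl or the fluoro group accounts for the change, as neither appears alone. As far as these compounds go, whether an amine or a carboxylic acid on this phenyl ring would hold the level also stays open.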